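This account rests on a few compounds, and the source may have more. Where it says the series, first, only, none or still open, it means among the compounds named here.

Measured compounds:
- compound 1 `CC(C)(C)c1ccc(-n2nc(-c3ccc(C(F)(F)F)cc3O)nc2-c2ccccc2O)cc1` gives 77.8%
- compound 2 `Oc1cc(C(F)(F)F)ccc1-c1nc(-c2ccccc2O)n(-c2ccccc2Cl)n1` gives 90.6%

Both numbers come from a functional assay on PC-12 cells (Rattus norvegicus) for cytotoxicity, read by MTT assay, with stated times of 2 h and 24 h, tested at 5 uM; a higher number here means a stronger effect of the compound at the concentration tested, a lower number a weaker effect. Of the two measured compounds, compound 2 stands highest, and its nearest neighbour is compound 1, which gave a number lower by a margin beyond the usual scatter.

Compound 3 `Cc1ccc(-n2nc(-c3ccc(C(F)(F)F)cc3O)nc2-c2ccccc2O)c(C)c1` keeps the shared core and differs from compound 2 at a single place: 2,4-dimethylphenyl in place of 2-chlorophenyl on an aromatic nitrogen.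

Among the measured compounds shown here, only one measured step touches the same place, the group on an aromatic nitrogen, and it ran a number 12.8 percentage points higher from compound 1 to compound 2 (beyond the scatter). That step exchanged one group for another at this spot, but neither of those groups is the 2,4-dimethylphenyl that enters here, so it offers no direct reading of the new group. The expectation is therefore a small step at most, estimated as a number 8.6 percentage points lower from compound 2 to compound 3 (within the scatter), within the scatter. On that basis compound 3 is expected to give about 82% in this assay, with a likely range from 68% to 94%.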

Compound 3, a percentage reported as activity, at one concentration (the size of the read-out at that concentration, not a potency): 93.3%
The estimate for compound 3 lay 11.3 percentage points below the measured number; low and high end bracket the measured number.
By their numbers in this assay, from the lowest: compound 1; then compounds 2 and 3 (each within the scatter of the next).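

In this assay, 2,4-dimethylphenyl in place of 2-chlorophenyl on the aromatic nitrogen gives a number 2.7 percentage points higher from compound 2 to compound 3 (within the scatter), so these two groups cannot be told apart, even though one ring carries chlorine and the other carries only carbon additions. Set against 4-(tert-butyl)phenyl, the same group gives a number 15.5 percentage points higher from compound 1 to compound 3 (beyond the scatter), so among these three compounds, compound 1 alone stands apart, while compound 2 and compound 3 sit together. Nothing available here explains why these groups compare as they do.

All three compounds carry a substituted phenyl ring at this nitrogen. On these data alone, it remains open whether a pyridine ring, or a phenyl ring bearing an amine or a carboxylic acid, would stay level with compound 2 and compound 3 or fall toward compound 1.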